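From 4-Chlorobenzyl to 2-Fluorobenzyl: an Expected Shift

The source may report more compounds than this note shows. Statements on the series, on what has been measured and on what is new or still open speak of the compounds shown alone.

Compound 2 `COc1cc(N)c(Cl)cc1NC(=O)C1CCN(Cc2ccc(Cl)cc2)CC1` is the only one of the three measured compounds that returns an actual number in a functional assay on the whole organism for antagonist activity, with Mus musculus as the target; on this read-out lower numbers stand for an effect already at smaller amounts and higher numbers for an effect only at larger amounts of compound: compound 2 gives 1.2 mg/kg. Compound 1 `CCCCCCCN1CCC(C(=O)Nc2cc(Cl)c(N)cc2OC)CC1` carries a hexyl group at the same place, and its value of > 10 mg/kg is a limit of the assay, not a number. Compound 3 `COc1cc(N)c(Cl)cc1NC(=O)C1CCN(Cc2ccc([N+](=O)[O-])cc2)CC1` likewise returns only a limit, > 4 mg/kg. The step of an at least 8.3-fold lower number from compound 1 to compound 2 (0.92 log units; beyond the scatter) shows that putting 4-chlorophenyl in place of hexyl matters, and the step of an at least 3.3-fold higher number from compound 2 to compound 3 (0.52 log units; beyond the scatter) shows that what sits on that aromatic ring matters as well, whereas a step that the two limits leave unreadable from compound 1 to compound 3.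

Compound 4 `COc1cc(N)c(Cl)cc1NC(=O)C1CCN(Cc2ccccc2F)CC1` differs from compound 2 by 2-fluorophenyl in place of 4-chlorophenyl on a saturated chain carbon bound to an amine nitrogen in a ring. For the measured compounds named here, no measured step touches a fluorine or a group placed as in 2-fluorophenyl, so the two steps around compound 2 only frame the question. Going by the values given here, the limits the limit of > 10 mg/kg in this assay, at which 1 of the 3 values shown sits, and the limit of > 4 mg/kg in this assay, at which 1 of the 3 values shown sits, both lie on the high side of the one number, so a change at this group seems more likely to raise the number than to lower it. For compound 4 the step of a 2.5-fold higher number from compound 2 to compound 4 (0.40 log units; beyond the scatter) is expected, a modest rise. Compound 4 is therefore estimated at 3 mg/kg, with a range from 1 mg/kg to 10 mg/kg.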

Compound 4, dose for half-maximal effect: > 4 mg/kg
Compound 4: only a limit was reported; the forecaster's own chance of this, stated with the estimate: 30%; middle value at least 1.3-fold (0.12 log units) from the limit.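

The change from 4-chlorobenzyl to 2-fluorobenzyl brings an at least 3.3-fold higher number from compound 2 to compound 4 (0.52 log units; beyond the scatter), so a second aromatic group on this saturated chain carbon bound to an amine nitrogen in a ring now fails to return a number in this assay. For the compounds shown here, until this result, the only comparison among aromatic groups at this place was nitro in place of chloro; a halogen on the ring now proves not to be enough on its own, as the fluorine-bearing group shows. Compound 4 returns only a limit, and this is the same limit as that of compound 3: the limit of > 4 mg/kg in this assay, at which 2 of the 4 values shown sit.

From the compounds shown here alone, the steps among compound 1, compound 3 and compound 4 run from limit to limit and cannot be read, so the order of hexyl, 4-nitrophenyl and 2-fluorophenyl at this place remains open. The change to compound 4 also replaces the halogen and moves it in a single step, and the compounds shown cannot separate the two; that would take 4-fluorophenyl or 2-chlorophenyl at the same place.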